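From 2-fluorobenzyl to 4-chlorobenzyl on a shared core

The source may hold more compounds than are shown below. What is called first, only, known or untested is meant among the compounds shown, and "the series" means these compounds.

Compound 1 `COC(=O)N1[C@@H]2C=C[C@@](OC)(C(=O)c3c2cc(OC)c(OC)c3OCc2ccccc2)N1C(=O)OC`: > 300 ug/mL, a limit
Compound 2 `COC(=O)N1[C@@H]2C=C[C@@](OC)(C(=O)c3c2cc(OC)c(OC)c3OCc2ccc(OC)cc2)N1C(=O)OC`: > 300 ug/mL, a limit
Compound 3 `COC(=O)N1[C@@H]2C=C[C@@](OC)(C(=O)c3c2cc(OC)c(OC)c3OCc2ccccc2F)N1C(=O)OC`: 137 ug/mL

All three were tested in an ADME assay on KB cells (Homo sapiens) for cytotoxicity; a lower number here means that less compound is needed, a higher number that more compound is needed for the effect. For the measured compounds named here, compound 3 stands alone as the only one with an actual number, at 137 ug/mL. The other two, compound 1 and compound 2, sit at the limit of > 300 ug/mL in this assay, at which 2 of the 3 values shown sit.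

Compound 4 `COC(=O)N1[C@@H]2C=C[C@@](OC)(C(=O)c3c2cc(OC)c(OC)c3OCc2ccc(Cl)cc2)N1C(=O)OC` has not yet been measured. It differs from compound 3 by 4-chlorophenyl in place of 2-fluorophenyl on a saturated chain carbon bound to an oxygen on an aromatic ring, with 4-chlorophenyl in place of 2-fluorophenyl on a saturated chain carbon bound to an oxygen on an aromatic ring.

Going by the values given here, two measured steps bear on this change: an at least 2.1-fold lower number from compound 1 to compound 3 (0.34 log units; beyond the scatter), and an at least 2.1-fold lower number from compound 2 to compound 3 (0.34 log units; beyond the scatter). Both led to the 2-fluorophenyl group, which compound 4 gives up. Neither step shows what a 4-chlorophenyl group does, so only a small move toward a higher number is expected: a 1.4-fold higher number from compound 3 to compound 4 (0.14 log units; within the scatter). For compound 4, the estimate is 190 ug/mL, with an expected range of 75 ug/mL to 400 ug/mL.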

Compound 4, concentration for half-maximal effect: 55.9 ug/mL
Beside the measured number, compound 4's estimate is 3.4-fold (0.53 log units) above it; measured number below the stated range.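

In this assay, the ring on this saturated chain carbon can take the number lower than the 2-fluorophenyl group did, with 4-chlorophenyl giving a 2.5-fold lower number from compound 3 to compound 4 (0.39 log units; beyond the scatter). Set against the plain benzyl group and the 4-methoxybenzyl group, the chloro group gives an at least 5.3-fold lower number from compound 1 to compound 4 (0.72 log units; beyond the scatter) and an at least 5.3-fold lower number from compound 2 to compound 4 (0.72 log units; beyond the scatter), the widest steps seen at this position. Both of those steps start from limits rather than numbers, and their full size remains unknown: the limit of > 300 ug/mL in this assay, at which 2 of the 4 values shown sit.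

The step to compound 4 changes the halogen and its place on the ring together, and the compounds shown do not separate these two changes. Also open, from the compounds shown here alone, is what a bromo group or a nitrile on this ring would do to the number.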